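The source may hold more compounds than are shown below. What is called first, only, known or untested is meant among the compounds shown, and "the series" means these compounds.

Measured so far:
compound 1, `N#Cc1cccc(F)c1-c1nc2ncccc2o1`: 50%
compound 2, `Fc1ccc(-c2nc3ncccc3o2)cc1`: 28%
compound 3, `N#Cc1ccccc1-c1nc2ncccc2o1`: 62%

In a functional assay on the whole organism for inhibition, with Rattus norvegicus as the target, at a dose of 30 mg/kg (a higher number here means more inhibition at the dose given (going by the name of the read-out), a lower number less inhibition), compound 3 gives 62%. Compound 1 carries one more fluoro group: fluoro in place of hydrogen on an aromatic carbon. That change produced a number 12 percentage points lower from compound 3 to compound 1 (beyond the scatter). Compound 2 is the lowest of the three in this assay, with compound 1 nearest and compound 3 furthest; the difference between the core of compound 2 and the core of compound 3 is not broken down here.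

The unmeasured compound 4, `Fc1ccc(-c2nc3ncccc3o2)c(F)c1`, arises from compound 2 by fluoro in place of hydrogen on an aromatic carbon. Among the measured compounds shown here, this is the same kind of change as the one from compound 3 to compound 1, not the same: in compound 1 the entering fluoro sits meta to a cyano group, in compound 4 meta to a fluoro group. The starting point is the value of compound 2, 28%. Since the earlier fluoro-for-hydrogen step in this assay lowered inhibition modestly, the step is expected to be a number 10 percentage points lower from compound 2 to compound 4 (within the scatter), resting on a number 12 percentage points lower from compound 3 to compound 1 (beyond the scatter). Compound 4 is therefore estimated at 18%, with a likely range from 4% to 34%.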

Compound 4, a percentage reported as inhibition, in the whole organism at one dose (the size of the read-out at that dose, not a potency): 23%
For compound 4 the middle estimate is 5 percentage points below the measured one; the range from low to high includes it.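

In this assay the fluoro-for-hydrogen change on the core of compound 2 gives a number 5 percentage points lower from compound 2 to compound 4 (within the scatter), so on this core it cannot be told from no change at all. The earlier step on the other core is the larger one as printed, yet the two cannot be told apart, and the change carries over from one core to the other without a detectable difference: the same change on two cores in this assay, a number 12 percentage points lower (beyond the scatter) from compound 3 to compound 1 and a number 5 percentage points lower (within the scatter) from compound 2 to compound 4, 7 percentage points apart, within the scatter of two such steps. Among the compounds shown here, this shows agreement between two pairs only; it fixes no size for the change on a further core, and it does not show that the change lowers inhibition on every core, since only one of the two steps lies beyond the scatter.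

The compounds shown leave open how a fluoro group placed elsewhere on the ring would read, since compound 4 covers only the place ortho to a group of 9 heavy atoms and meta to a fluoro group. They also leave open whether a chloro group, a methoxy group or an amine in that place would follow the same course.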